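This account rests on a few compounds, and the source may have more. Where it says the series, first, only, none or still open, it means among the compounds named here.

Measured compounds in an in vitro assay on BHK cells for inhibition of Glucagon receptor (Homo sapiens); on this read-out higher numbers stand for weaker inhibition and lower numbers for stronger inhibition:
compound 1 `CC(C)c1ccc(NC(=O)N(Cc2ccc(C(=O)NCCC(=O)O)cc2)[C@H]2CC[C@H](C(C)(C)C)CC2)cc1`: 35 nM
compound 2 `CC(C)(C)[C@H]1CC[C@H](N(Cc2ccc(C(=O)NCCC(=O)O)cc2)C(=O)Nc2cc(Cl)cc(Cl)c2)CC1`: 80 nM
compound 3 `CCCCC(CC)N(Cc1ccc(C(=O)NCCC(=O)O)cc1)C(=O)Nc1ccc(OC(F)(F)F)cc1`: 141 nM

Compound 3 stands at the upper end of the three numbers in this assay. Against compound 2 the difference is within the scatter; against compound 1 it is beyond the scatter. Within the data shown here, the only step between measured compounds that differ in one place is a 2.3-fold higher number from compound 1 to compound 2 (0.36 log units; beyond the scatter). That step concerns the aryl group on the other amide-type nitrogen and does not bear directly on the change considered here.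

Compound 4 `CCCC1CCC(N(Cc2ccc(C(=O)NCCC(=O)O)cc2)C(=O)Nc2ccc(OC(F)(F)F)cc2)CC1` differs from compound 3 by 4-propylcyclohexyl in place of 1-ethylpentyl on an amide-type nitrogen. Among the measured compounds shown here, no measured pair isolates this change. What the set does show is that compounds 1 and 2, each carrying a six-membered non-aromatic ring of carbon only on an amide-type nitrogen, give lower numbers than compound 3; since they also differ in the aryl part, this is only indirect support, and compound 4 carries no defined ring stereochemistry. A modest decrease in number is therefore expected, a 1.8-fold lower number from compound 3 to compound 4 (0.25 log units; within the scatter), with wide uncertainty. Compound 4 is estimated at 80 nM in this assay, in the range 30 nM to 220 nM.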

Compound 4, half-maximal inhibitory concentration: 122 nM
Compound 4: middle estimate off by 1.5-fold (0.18 log units), on the low side; low and high end bracket the measured number.
By their numbers in this assay, from the lowest: compound 1; then compounds 2, 4 and 3 (each within the scatter of the next).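

In this assay, among these compounds, 4-propylcyclohexyl in place of 1-ethylpentyl on an amide-type nitrogen comes out as a 1.2-fold lower number from compound 3 to compound 4 (0.06 log units; within the scatter), the first step that isolates this position. In this one pair, the read-out does not separate an open chain of 7 heavy atoms from a group of 9 heavy atoms with a six-membered non-aromatic ring of carbon only, so the ring alone does not move the number beyond the scatter with the 4-(trifluoromethoxy)phenyl urea part held constant. No measurement at hand speaks to why these two groups fall within the scatter of each other.

Still open, as far as these compounds go, is whether a defined ring stereochemistry in 4-propylcyclohexyl would read differently from compound 4, which carries none, and whether the outcome of this swap holds with another aryl group on the other amide-type nitrogen. The compounds shown also leave open how this position responds to a group that is not purely carbon, such as a cyclohexyl ring bearing a hydroxyl or an amine.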